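Lengthening the chain of compound 1

This account rests on a few compounds, and the source may have more. Where it says the series, first, only, none or still open, it means among the compounds named here.

In a functional assay on SW480 cells (Homo sapiens) for antiproliferative activity, read by MTT assay, with a stated time of 48 h (a lower number here means a stronger inhibitor, a higher number a weaker inhibitor), compound 1 (`CCCCCC(CCO)n1cnc2c(OC)ncnc21`) gives > 50000 nM, which is a limit and not a number. Compound 2 (`CCCCCC(CCO)n1cnc2c(N)ncnc21`), with amino in place of methoxy on an aromatic carbon, gives > 50000 nM, which is also a limit. The evidence so far is the limit of > 50000 nM in this assay, at which 2 of the 2 values shown sit. For the measured compounds named here, the only measured step is a step that the two limits leave unreadable from compound 1 to compound 2, so it offers no size to carry forward, and it concerns an aromatic carbon, not the chain.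

Compound 3 (`CCCCCCCC(CCO)n1cnc2c(OC)ncnc21`) differs from compound 1 by ethyl in place of hydrogen on a saturated chain carbon, six bonds along the chain from an aromatic nitrogen, which is ethyl in place of hydrogen on a saturated chain carbon, six bonds along the chain from an aromatic nitrogen. Going by the values given here, no measured step covers this change, so the expectation is a loose judgement that starts from the limit of compound 1 at > 50000 nM. In this assay, the expected step of an at least 1.2-fold lower number from compound 1 to compound 3 (0.09 log units; that floor lies within the scatter) is small and towards a lower number, and another limit remains quite likely. For compound 3 the estimated value is 40000 nM, with an expected range of 12000 nM to 100000 nM.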

Compound 3, half-maximal inhibitory concentration: 23900 nM
Beside the measured number, compound 3's estimate is 1.7-fold (0.22 log units) above it; the range from low to high includes it.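

In this assay, ethyl in place of hydrogen on a saturated chain carbon, six bonds along the chain from an aromatic nitrogen, gives an at least 2.0-fold lower number from compound 1 to compound 3 (0.32 log units; beyond the scatter), so this position on the chain is one where a change in the series can be read, and the longer chain goes with the lower number. One end of that step is a limit, so its size is a floor and not a measured difference. Compound 3 is the only compound shown with a number rather than a limit, and the remaining compounds give no second number to set it against: the limit of > 50000 nM in this assay, at which 2 of the 3 values shown sit.

From the compounds shown here alone, the step from methoxy to amino cannot be read, so the effect of amino on the longer chain of compound 3 remains unknown, and the methoxy group's role in the number for compound 3 is equally open. Also open, going by these compounds, are whether a still longer chain at this position carries the number lower, and whether an amine or a carboxylic acid in place of the hydroxyl keeps the gain seen with ethyl.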